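Butoxy in Place of Ethyl on a Shared Core

The compounds below may be only part of what the source reports. "The series", "measured", "known", "first", "only" and "open" are said of these compounds alone.

Compound 1 `Cc1cc(Nc2cc(Cl)cc(Cl)c2)ncn1` reaches in an assay on cells for inhibition of S-adenosylmethionine decarboxylase proenzyme (Homo sapiens), read by mass spectrometry, at pH 7.2 (on this read-out higher numbers stand for weaker inhibition and lower numbers for stronger inhibition), only the limit > 180000 nM.
Compound 2 `CCc1cc(Br)cc(Nc2cc(C)nc(N)n2)c1` reaches in this assay only the limit > 180000 nM.

Compound 2 stands at the edge of what was measured: its result in this assay is a limit and not a number, and the other measured result is a limit as well, so that the limit of > 180000 nM in this assay, at which 2 of the 2 values shown sit, is the whole of the evidence. No step between two measured compounds can be drawn from this, and no trend toward stronger or weaker inhibition is shown.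

Compound 3 `CCCCOc1cc(Br)cc(Nc2cc(C)nc(N)n2)c1` differs from compound 2 in one place: butoxy in place of ethyl on an aromatic carbon. With both measured results sitting at the same limit, there is nothing to suggest that this exchange would move the result beyond the usual scatter in either direction. Compound 3 is therefore expected to come out where compound 2 sits, most likely again as a limit. The estimated value in this assay for compound 3 is 200000 nM, within a range from 50000 nM to 1000000 nM. The expected step is a step that the limit leaves unreadable from compound 2 to compound 3, none beyond the scatter.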

Compound 3, half-maximal inhibitory concentration: > 180000 nM
Compound 3 gave a limit, no number (the forecaster's own chance of this, stated with the estimate: 80%); the middle value is on the limit's open side.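

Compound 3, like compound 2, gives only a limit in this assay, so no step between compound 2 and compound 3 can be read for butoxy in place of ethyl, and the whole of the evidence is this: the limit of > 180000 nM in this assay, at which 3 of the 3 values shown sit.

The compounds shown leave open what butoxy in place of ethyl does to inhibition, and whether any related compound gives a number rather than a limit in this assay.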